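Cyclohexyl for pentan-3-yl on the enone chain

The source may report more compounds than this note shows. Statements on the series, on what has been measured and on what is new or still open speak of the compounds shown alone.

Measured so far: compound 1 `COc1ccc(C(=O)/C(=C/C2CCCCC2)COC(C)=O)cc1`, compound 2 `COc1ccc(C(=O)/C(=C/C2CCCCC2)COC(=O)c2ccccc2)cc1`, compound 3 `CCC(/C=C(\CCOC(C)=O)C(=O)c1ccc(OC)cc1)CC`.

In a functional assay on NB-4 cells (Homo sapiens) for inhibition, read by XTT assay, with a stated time of 48 h (on this read-out higher numbers stand for weaker inhibition and lower numbers for stronger inhibition), compound 1 gives 23300 nM, compound 2 gives 10200 nM and compound 3 gives 91100 nM. Among the measured compounds shown here, compound 3 thus stands highest of the three; the one step measured in one place, a 2.3-fold lower number from compound 1 to compound 2 (0.36 log units; beyond the scatter), concerns the ester carbonyl and does not bear on the present change. Compound 4 `COc1ccc(C(=O)/C(=C/C2CCCCC2)CCOC(C)=O)cc1` differs from compound 3 by cyclohexyl in place of pentan-3-yl on a double-bonded chain carbon bound to a double-bonded chain carbon. For the measured compounds named here, compound 1 also carries cyclohexyl but with a shorter ester-bearing chain, so no single measured step matches this change; the gap between compound 3 and compound 1 is the only guide. The expected step, a 2.3-fold lower number from compound 3 to compound 4 (0.36 log units; beyond the scatter), is a moderate lowering in this assay, short of compound 1. Compound 4 is expected at 40000 nM, range 15000 nM to 110000 nM.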

Compound 4, half-maximal inhibitory concentration: > 100000 nM
Compound 4 gave a limit, no number (the forecaster's own chance of this, stated with the estimate: 5%); at least 2.5-fold (0.39 log units) between middle value and limit.
By their numbers in this assay, from the lowest: compound 2; then compound 1; then compound 3. At a limit, above all of these: compound 4.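

In this assay compound 4 gives > 100000 nM, a limit and not a number. With cyclohexyl held, the longer acetoxy chain costs activity, an at least 4.2-fold higher number from compound 1 to compound 4 (0.63 log units; beyond the scatter), and the comparison with the benzoate points the same way, an at least 9.8-fold higher number from compound 2 to compound 4 (0.99 log units; beyond the scatter). The cyclohexyl for pentan-3-yl change itself shows no readable direction: an at least 1.0-fold higher number from compound 3 to compound 4 (0.04 log units; that floor lies within the scatter).

Going by these compounds, the true order of compound 3 and compound 4 stays unknown. Also open, on these data alone, is how an amine or a carboxylic acid in place of the ester on this chain would read.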